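Replacing the aryl ether of compound 2 with a benzyl group

The source may hold more compounds than are shown below. What is called first, only, known or untested is meant among the compounds shown, and "the series" means these compounds.

Measured compounds in an assay for inhibition of prostacyclin synthase (Homo sapiens), using microsomes; on this read-out higher numbers stand for weaker inhibition and lower numbers for stronger inhibition:
- compound 1, `CSc1ccc(OC(C)(C)C2OCC(C/C=C\CCC(=O)O)C(c3cccnc3)O2)c([N+](=O)[O-])c1`: compound 1 gives 5000 nM
- compound 2, `CSc1ccccc1OC(C)(C)C1OCC(C/C=C\CCC(=O)O)C(c2cccnc2)O1`: compound 2 gives only a limit, > 100000 nM
- compound 3, `COc1ccc(OC(C)(C)C2OCC(C/C=C\CCC(=O)O)C(c3cccnc3)O2)c([N+](=O)[O-])c1`: compound 3 gives 23000 nM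

Compound 2 stands at the weak end of the series; its value is a limit of this assay and not a number, namely (the limit of > 100000 nM in this assay, at which 1 of the 3 values shown sits). The step from compound 1 shows how it got there: an at least 20-fold higher number from compound 1 to compound 2 (1.30 log units; beyond the scatter), and the reverse direction appears again in an at least 4.3-fold lower number from compound 2 to compound 3 (0.63 log units; beyond the scatter). Within the aryl ethers, a 4.6-fold higher number from compound 1 to compound 3 (0.66 log units; beyond the scatter).

Compound 4, `CC(C)(Cc1ccc(F)cc1C#N)C1OCC(C/C=C\CCC(=O)O)C(c2cccnc2)O1`, is not yet measured. The change is a group of 10 heavy atoms (8 carbon, 1 nitrogen, 1 fluorine; one six-membered aromatic ring of carbon only) in place of a group of 9 heavy atoms (7 carbon, 1 oxygen, 1 sulfur; one six-membered aromatic ring of carbon only), on a saturated chain carbon bound to two saturated chain carbons and a saturated ring carbon. For the measured compounds named here, no measured step touches this change: all three measured compounds keep an oxygen on the saturated carbon, and none carries a nitrile or a fluorine. The measured steps only show that the aryl group on that position moves this assay by large amounts, in both directions. Because compound 2 gives only a limit, > 100000 nM, the step to compound 4 can only be bounded from one side.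

Compound 4 is expected to give 30000 nM in this assay, range 5000 nM to 150000 nM. The estimated step is an at least 3.3-fold lower number from compound 2 to compound 4 (0.52 log units; beyond the scatter), with a real chance that compound 4 also returns only a limit.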

Compound 4, half-maximal inhibitory concentration: 7000 nM
Compound 4: the middle estimate sits 4.3-fold (0.63 log units) above what was measured, and the stated range covers the measured number.
By their numbers in this assay, from the lowest: compounds 1 and 4 (each within the scatter of the next); then compound 3. At a limit, above all of these: compound 2.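

In this assay, an aryl group on the saturated chain carbon does not need an ether oxygen for measurable inhibition: the change to the nitrile- and fluorine-bearing benzyl group gives an at least 14-fold lower number from compound 2 to compound 4 (1.15 log units; beyond the scatter). Compound 1 gives 5000 nM and compound 4 gives 7000 nM, values within the scatter of each other, so a nitro group is not needed to reach this level among the compounds shown. The value of compound 2 is a limit and not a number, so the true size of the step stays unknown: the limit of > 100000 nM in this assay, at which 1 of the 4 values shown sits.

On these data alone, the change removes the oxygen and the methylsulfanyl group and adds the nitrile and the fluorine in one step, so the share of each stays open. Also open, as far as these compounds go, is how a carboxamide in place of the nitrile, or a longer chain to the aryl ring, would read.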